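A few compounds are considered here, and "the series" means these few. Any claim that something is new, unique, unknown or untested is made for them only; others in the source may bear on it.

Measured in a functional assay on MCF7 cells (Homo sapiens) for antiproliferative activity, read by MTT assay, with a stated time of 72 h (on this read-out higher numbers stand for weaker inhibition and lower numbers for stronger inhibition), so far
compound 1 `COc1ccc(N2C(=O)COc3ccc(-c4cnc(Cl)c(NS(=O)(=O)c5ccc(F)cc5)c4)cc32)cc1` gives 36000 nM
compound 2 `CC(C)N1C(=O)COc2ccc(-c3cnc(Cl)c(NS(=O)(=O)c4ccc(F)cc4)c3)cc21` gives 26600 nM
compound 3 `COc1ncc(-c2ccc3c(c2)N(c2ccccc2)C(=O)CO3)cc1NS(=O)(=O)c1ccc(F)cc1` gives 8870 nM

Compound 3 holds the lowest of the three numbers, and its gaps to compound 1 and compound 2 both lie beyond the scatter. Compound 4 `O=C1COc2ccc(-c3cnc(Cl)c(NS(=O)(=O)c4ccc(F)cc4)c3)cc2N1c1ccccc1` is compound 3 with one change on an aromatic carbon, chloro in place of methoxy on an aromatic carbon.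

Among the measured compounds shown here, the only measured step, a 1.4-fold lower number from compound 1 to compound 2 (0.13 log units; within the scatter), concerns the group on the amide-type nitrogen and stays within the scatter. For the measured compounds named here, no measured step exchanges methoxy for chloro directly, and compound 3 differs from compound 1 and compound 2 in more than one place. Even so, compound 1 and compound 2 both carry chloro, both show higher numbers than compound 3, and the nitrogen group seems to matter little between them. A rise beyond the scatter is therefore expected, with the estimated change being a 2.8-fold higher number from compound 3 to compound 4 (0.45 log units; beyond the scatter) in this assay. For compound 4 the estimate is 25000 nM with an expected range from 11000 nM to 55000 nM in the same read-out.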

Compound 4, half-maximal inhibitory concentration: > 40000 nM
Compound 4 gave a limit, no number (the forecaster's own chance of this, stated with the estimate: 10%); middle value at least 1.6-fold (0.20 log units) from the limit.
By their numbers in this assay, from the lowest: compound 3; then compounds 2 and 1 (each within the scatter of the next). At a limit, above all of these: compound 4.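

In this assay compound 4 gives > 40000 nM, which is a limit and not a number. Among the compounds shown here, this is the first direct reading of the change on the aromatic carbon next to the ring nitrogen, with phenyl held on the amide-type nitrogen: an at least 4.5-fold higher number from compound 3 to compound 4 (0.65 log units; beyond the scatter), a step that is at least modest, so in this read-out methoxy at this position gives the lower number and chloro the higher one. The two other new steps are an at least 1.5-fold higher number from compound 2 to compound 4 (0.17 log units; that floor lies within the scatter) and an at least 1.1-fold higher number from compound 1 to compound 4 (0.04 log units; that floor lies within the scatter); both rest on floors that lie within the scatter, so neither can be read further.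

With only methoxy and chloro shown on this carbon, it stays open how an amino group, a hydroxyl or an ethoxy group would read there. Also open, as far as these compounds go, is whether the same exchange holds with isopropyl or 4-methoxyphenyl on the amide-type nitrogen.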